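A few compounds are considered here, and "the series" means these few. Any claim that something is new, unique, unknown or untested is made for them only; others in the source may bear on it.

Two compounds of the series have readings so far. In a functional assay on PC-3 cells (Homo sapiens) for cytotoxicity, read by colorimetric assay and MTT assay (a lower number here means a stronger inhibitor, a higher number a weaker inhibitor), compound 1 (`COc1ccc(-c2cc3c(OC)ccc(OC)c3nc2O)cc1`) gives 10000 nM as its half-maximal inhibitory concentration, and compound 2 (`CCOC(=O)Cn1c(=O)c(-c2ccc(OC)cc2)cc2c(OC)cc(OC)cc21`) gives 10000 nM on the same read-out, so compound 2 stands level with compound 1 at the digits shown.

Compound 3 (`COc1ccc(-c2cc3c(OC)cc(OC)cc3n(CCC#N)c2=O)cc1`) has no reading yet. Its structure departs from compound 2 at one place, with cyanomethyl in place of ethoxycarbonyl on a saturated chain carbon bound to an aromatic nitrogen as the counted difference, that is, cyanomethyl in place of ethoxycarbonyl on a saturated chain carbon bound to an aromatic nitrogen. Cut one bond further out, the same difference reads (ethoxycarbonyl)methyl to 2-cyanoethyl.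

For the measured compounds named here, no measured pair isolates a change at one place, so the data hold no direct reading on this replacement. With compound 2 at 10000 nM as the starting point, no step beyond the scatter is expected in this assay in either direction. The estimate amounts to no change at the digits printed from compound 2 to compound 3 (within the scatter) and is expected to stay within the scatter. For compound 3 the estimated value is 10000 nM with an expected range from 3500 nM to 25000 nM on this read-out.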

Compound 3, half-maximal inhibitory concentration: 10000 nM
Compound 3: middle estimate and measured number agree at the digits printed, and the stated range covers the measured number.
By their numbers in this assay, from the lowest: compounds 1, 2 and 3 (each within the scatter of the next).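

In this assay, the replacement of ethoxycarbonyl by cyanomethyl on a saturated chain carbon bound to an aromatic nitrogen gives no change at the digits printed from compound 2 to compound 3 (within the scatter), and this is the only step in the compounds shown that isolates a change at one place. At this position, the difference between (ethoxycarbonyl)methyl and 2-cyanoethyl therefore leaves the reading within the scatter, even though the entering group has 3 heavy atoms and 1 hydrogen-bond acceptor, against 5 heavy atoms and 2 hydrogen-bond acceptors for the group it replaces. No measurement on hand bears on why the two compounds read alike.

As far as these compounds go, it remains open whether any group at this place can move the reading in this assay, for example a carboxylic acid, a primary amine or a longer alkyl chain. Also open, from the compounds shown here alone, is whether the same replacement would read alike on the core of compound 1, whose methoxy groups are placed differently.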